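The source may report more compounds than this note shows. Statements on the series, on what has been measured and on what is new or still open speak of the compounds shown alone.

Three compounds built on closely related cores were tested in a functional assay on HT-29 cells (Homo sapiens) for cytotoxicity, read by sulforhodamine B assay, with a stated time of 48 h; on this read-out higher numbers stand for weaker inhibition of growth and lower numbers for stronger inhibition of growth. Compound 3 `ClCc1cccc(Cn2cnc3nc(Cl)nc(Cl)c32)c1` gives 340 nM in this assay. Compound 1 `ClCc1cccc(Cn2cnc3ncnc(Cl)c32)c1` gives 2880 nM, and compound 2 `ClCc1ccc(Cn2cnc3nc(Cl)nc(Cl)c32)cc1` gives 3540 nM; the values of compound 1 and compound 2 lie within the scatter of each other.

Compound 1 arises from compound 3 by one change, (hydrogen in place of chloro on an aromatic carbon), and that change brought an 8.5-fold higher number from compound 3 to compound 1 (0.93 log units; beyond the scatter). The difference between the core of compound 2 and the core of compound 3 is not broken down here.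

Compound 4 `ClCc1ccc(Cn2cnc3ncnc(Cl)c32)cc1` has not yet been measured. It arises from compound 2 by hydrogen in place of chloro on an aromatic carbon, the same change that turns compound 3 into compound 1, at a place described in the same words. On that one precedent, the step from compound 2 to compound 4 in this assay is expected to be a 4.2-fold higher number from compound 2 to compound 4 (0.63 log units; beyond the scatter), a weakening of growth inhibition, because compound 3 gave 340 nM while compound 1 gave 2880 nM. Compound 4 is therefore estimated at about 15000 nM, with a plausible range from 5000 nM to 50000 nM, since a single precedent leaves the size uncertain.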

Compound 4, concentration for 50% growth inhibition: 1230 nM
For compound 4 the middle estimate is 12-fold (1.09 log units) above the measured one; the measured number lies below the stated range.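

In this assay, putting hydrogen in place of the chloro on the aromatic carbon between two ring nitrogen atoms gave a 2.9-fold lower number from compound 2 to compound 4 (0.46 log units; beyond the scatter), so removing this chloro went along with stronger inhibition of growth on this core and weaker inhibition on the other. The effect of this change therefore did not carry over from one core to the other, in size or in direction: the same change on two cores in this assay, an 8.5-fold higher number (0.93 log units; beyond the scatter) from compound 3 to compound 1 and a 2.9-fold lower number (0.46 log units; beyond the scatter) from compound 2 to compound 4, 24-fold (1.39 log units) apart, beyond the scatter of two such steps. This shows that, in this series, the result of the change depends on the core that carries it, but two pairs of compounds cannot show why the steps part ways or predict the direction on any further core.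

Still open, as far as these compounds go, is how an amine or a methoxy group on that same carbon would compare with chloro and hydrogen on each core. Also open, from the compounds shown here alone, is whether a third core would follow either of these two pairs or behave differently from both.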